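A few compounds are considered here, and "the series" means these few. Any claim that something is new, unique, unknown or untested is made for them only; others in the source may bear on it.

Two related compounds have been examined so far in a functional assay on MDA-MB-231 cells (Homo sapiens) for antiproliferative activity, read by MTT assay, with a stated time of 72 h (on this read-out higher numbers stand for weaker inhibition and lower numbers for stronger inhibition), and only one of them gives a number. For compound 1 `COc1ccc(OCCCON2C(N)=NC(N)=NC23CCOCC3)cc1` the entry reads "not determined" (no result reported), so no result is available from it. Going by the values given here, compound 2 `NC1=NC2(CCSCC2)N(OCCCOc2cccc(Cl)c2Cl)C(N)=N1` gives 1 nM, which is the only value on hand, and it therefore has no measured neighbour to be ranked against.

The next compound to be tested is compound 3 `COc1ccc(OCCCON2C(N)=NC(N)=NC23CCSCC3)cc1`, which has not yet been measured. It departs from compound 2 in a single place, where 4-methoxyphenyl stands in place of 2,3-dichlorophenyl on an oxygen on a saturated carbon: 4-methoxyphenyl in place of 2,3-dichlorophenyl on an oxygen on a saturated carbon.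

Among the compounds with values here, no pair of measured compounds shows what a change of this kind does in this assay, so any forecast is loose. With compound 2 at 1 nM, a moderate loss of potency seems more likely than a gain, although a result within the usual scatter cannot be excluded. The expected weakening is estimated as a 6.0-fold higher number from compound 2 to compound 3 (0.78 log units; beyond the scatter). Compound 3 is expected to give about 6 nM, with an estimated range of 1 nM to 40 nM.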

Compound 3, half-maximal inhibitory concentration: 350 nM
Beside the measured number, compound 3's estimate is 58-fold (1.77 log units) below it; measured number outside the range, above it.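

In this assay, going by these compounds alone, the exchange of 2,3-dichlorophenyl for 4-methoxyphenyl on an oxygen on a saturated carbon gives a 350-fold higher number from compound 2 to compound 3 (2.54 log units; beyond the scatter) and so shows that this position strongly affects the read-out, which the earlier compounds could not show. The leaving and entering groups have the same count of heavy atoms and each holds one six-membered aromatic ring of carbon only, so the large weakening arises without removal of the ring; what changes is that two chlorine atoms are gone and the entering group carries a hydrogen-bond acceptor. Nothing at hand bears on the reason for this loss.

Within the data shown here, the single step cannot tell whether the weakening follows from losing the chlorine atoms, from gaining the methoxy group, or from where these substituents sit on the ring, and how a plain phenyl or a 2-chlorophenyl group would read at this place remains open. From the compounds shown here alone, it also remains open whether the exchange carries the same weight on the core of compound 1, whose entry gives no number.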